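The source may hold more compounds than are shown below. What is called first, only, known or untested is meant among the compounds shown, and "the series" means these compounds.

Values so far in a functional assay on MOLT-4 cells (Homo sapiens) for antiproliferative activity; on this read-out lower numbers stand for stronger inhibition and higher numbers for weaker inhibition:
- compound 1 `COc1ccc(-c2cc(N)c(C(=O)c3cc(OC)c(OC)c(OC)c3)s2)cc1OC` gives 20 nM
- compound 2 `COc1cc(C(=O)c2sc(-c3ccncc3)cc2N)cc(OC)c1OC` gives 88 nM
- compound 3 `COc1cc(C(=O)c2sc(-c3ccccc3Cl)cc2N)cc(OC)c1OC` gives 17 nM

Compound 3 sits at the low end of these numbers, and the two steps into it are (a 1.2-fold lower number from compound 1 to compound 3 (0.07 log units; within the scatter)) and (a 5.2-fold lower number from compound 2 to compound 3 (0.71 log units; beyond the scatter)).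

Next is compound 4 `COc1cc(C(=O)c2sc(-c3ccsc3)cc2N)cc(OC)c1OC`, with thiophen-3-yl in place of 2-chlorophenyl on an aromatic carbon. Going by the values given here, the only guides are the other swaps at this same place. Exchanging one substituted phenyl for another moved nothing beyond the scatter, as the step into compound 3 shows, while the pyridin-4-yl swap gave a modest step (a 4.4-fold higher number from compound 1 to compound 2 (0.64 log units; beyond the scatter)). No five-membered ring has been measured at this place, so the guidance is indirect. A rise smaller than the pyridin-4-yl step is expected in this assay and quite possibly none beyond the scatter. The estimated step reads (a 1.8-fold higher number from compound 3 to compound 4 (0.25 log units; within the scatter)). Compound 4 is expected at 30 nM (estimated range 10 nM to 90 nM).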

Compound 4, half-maximal inhibitory concentration: 8.8 nM
The estimate for compound 4 lay 3.4-fold (0.53 log units) above the measured number; the measured number lies below the stated range.
By their numbers in this assay, from the lowest: compounds 4, 3 and 1 (each within the scatter of the next, the first and the last beyond it); then compound 2.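

In this assay, a five-membered aromatic ring with one sulfur is accommodated on the aromatic carbon next to the ring sulfur: thiophen-3-yl cannot be told apart from 2-chlorophenyl (a 1.9-fold lower number from compound 3 to compound 4 (0.29 log units; within the scatter)). Unlike the earlier exchange of 3,4-dimethoxyphenyl for 2-chlorophenyl, replacing 3,4-dimethoxyphenyl with thiophen-3-yl clears the scatter (a 2.3-fold lower number from compound 1 to compound 4 (0.36 log units; beyond the scatter)), and the gap to pyridin-4-yl widens to the largest step seen at this place (a 10-fold lower number from compound 2 to compound 4 (1.00 log units; beyond the scatter)). No measured evidence accompanies these steps to account for them.

Still open, going by these compounds, is whether thiophen-2-yl or furan-3-yl would stay level with thiophen-3-yl. Also open, on these data alone, is how an aminomethyl or carboxylic acid group on the ring at this place would shift the number.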